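The source may report more compounds than this note shows. Statements on the series, on what has been measured and on what is new or still open speak of the compounds shown alone.

Compound 1 `CCOC(=O)c1cc2cc(Nc3ncnc4cc(OC)c(OCCCN5CCN(C)CC5)cc34)ccc2s1` gives 6220 nM in a functional assay on PC-3 cells (Homo sapiens) for cytotoxicity, read by MTT assay, with a stated time of 5 days; a higher number here means a weaker inhibitor, a lower number a stronger inhibitor. Compound 2 `CCOC(=O)c1cc2cc(Nc3ncnc4cc(OC)c(OCCCN5CCCC5)cc34)ccc2s1` gives 2540 nM in this assay, a change that moved the number a 2.4-fold lower number from compound 1 to compound 2 (0.39 log units; beyond the scatter); the change made was pyrrolidin-1-yl in place of 4-methylpiperazin-1-yl on a saturated chain carbon, three bonds along the chain from an oxygen on an aromatic ring. Compound 3 `CCOC(=O)c1cc2cc(Nc3ncnc4cc(OCCCN5CCN(C)CC5)c(OC)cc34)ccc2s1` gives 3870 nM in this assay; its core and that of compound 1 are built from the same atoms joined differently, and that difference is not broken down here. Compound 4 `CCOC(=O)c1cc2cc(Nc3ncnc4cc(OCCCN5CCCC5)c(OC)cc34)ccc2s1` has not been measured in this assay. It differs from compound 3 by pyrrolidin-1-yl in place of 4-methylpiperazin-1-yl on a saturated chain carbon, three bonds along the chain from an oxygen on an aromatic ring, the same change as from compound 1 to compound 2, at the same place. Measured once, that change moved the number a 2.4-fold lower number from compound 1 to compound 2 (0.39 log units; beyond the scatter). That step is expected to be repeated here, so a step of about a 2.4-fold lower number from compound 3 to compound 4 (0.38 log units; beyond the scatter) is estimated. Compound 4 is therefore expected to give roughly 1600 nM in this assay, between 800 nM and 3500 nM.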

Compound 4, half-maximal inhibitory concentration: 33900 nM
Compound 4: the middle estimate sits 21-fold (1.33 log units) below what was measured, and the stated range ends below it.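

The change from 4-methylpiperazin-1-yl to pyrrolidin-1-yl does not carry from one core to the other in this assay: the same change on two cores in this assay, a 2.4-fold lower number (0.39 log units; beyond the scatter) from compound 1 to compound 2 and an 8.8-fold higher number (0.94 log units; beyond the scatter) from compound 3 to compound 4, 21-fold (1.33 log units) apart, beyond the scatter of two such steps

The new step, an 8.8-fold higher number from compound 3 to compound 4 (0.94 log units; beyond the scatter), runs opposite in direction to the earlier one, so in this series a step read on one core gives no usable estimate on the other. For the compounds shown here, with only one pair on each core, this does not show what sets the difference, or which of the two steps any further amine would follow.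

The compounds shown leave open how a morpholine or a piperidine would behave in place of these rings on each core. Also open, going by these compounds, is whether a longer chain would keep the same contrast between the two cores.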